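Cyclopropyl to phenyl on the triazole substituent of compound 1

The source may hold more compounds than are shown below. What is called first, only, known or untested is meant among the compounds shown, and "the series" means these compounds.

The series shares one core; compound 1 `COc1nc2ccc(Br)cc2cc1C(c1ccccc1)n1cc(C2CC2)nn1` carries a cyclopropyl on the five-membered aromatic ring. In an ADME assay on PANC-1 cells (Homo sapiens) for cytotoxicity, read by sulforhodamine B assay, with a stated time of 48 h, tested at 10 uM (on this read-out higher numbers stand for more inhibition at the one concentration tested (going by the name of the read-out) and lower numbers for less inhibition), compound 1 gives 21.8%. Compound 2 `COc1nc2ccc(Br)cc2cc1C(c1ccccc1)n1cc(CO)nn1` gives 15%, and compound 3 `COc1nc2ccc(Br)cc2cc1C(c1ccccc1)n1cc(CCO)nn1` gives 19.8%. Compound 1 gives the largest of the three numbers, but the gaps are small: a number 6.8 percentage points lower from compound 1 to compound 2 (within the scatter) and a number 2 percentage points lower from compound 1 to compound 3 (within the scatter), and a number 4.8 percentage points higher from compound 2 to compound 3 (within the scatter). All three values sit inside the scatter of one another, so no ordering among them can be claimed.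

Compound 4 `COc1nc2ccc(Br)cc2cc1C(c1ccccc1)n1cc(-c2ccccc2)nn1` has not yet been measured. The change from compound 1 is phenyl in place of cyclopropyl on an aromatic carbon. Within the data shown here, the two measured steps away from the cyclopropyl of compound 1 both stayed within the scatter, but both put in a hydroxyl-bearing chain; no measured step puts an aromatic ring at this position, so the data give no direct guide for phenyl. Among the measured compounds shown here, with no step so far beyond the scatter, the expected step of a number 0.2 percentage points higher from compound 1 to compound 4 (within the scatter) is none beyond the scatter. Compound 4 is therefore estimated at 22%, expected within 10% to 34%.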

Compound 4, a percentage reported as inhibition, at one concentration (the size of the read-out at that concentration, not a potency): 30.1%
For compound 4 the middle estimate is 8.1 percentage points below the measured one, and the stated range covers the measured number.
By their numbers in this assay, from the lowest: compounds 2, 3, 1 and 4 (each within the scatter of the next, the first and the last beyond it).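

In this assay, this position on the five-membered aromatic ring gives its first steps beyond the scatter, both modest: with phenyl in place of hydroxymethyl there is a number 15.1 percentage points higher from compound 2 to compound 4 (beyond the scatter), and with phenyl in place of 2-hydroxyethyl there is a number 10.3 percentage points higher from compound 3 to compound 4 (beyond the scatter). Against cyclopropyl, the same phenyl gives a number 8.3 percentage points higher from compound 1 to compound 4 (within the scatter), so the larger aromatic ring is not separated from the three-membered ring on this read-out, and the steps beyond the scatter are confined to the two hydroxyl-bearing chains. No measurement on hand gives a reason for these differences.

As far as these compounds go, how a substituted phenyl, a pyridine ring, an amine or a carboxylic acid would read at this position remains open. From the compounds shown here alone, these are readings at one concentration, so any difference in potency also remains open.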